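The source may report more compounds than this note shows. Statements on the series, on what has been measured and on what is new or still open speak of the compounds shown alone.

Measured in an assay on cells for inhibition of high affinity 3',5'-cyclic-AMP phosphodiesterase 7A (Homo sapiens), read by scintillation counting and cAMP accumulation, with a stated time of 30 min; a lower number here means a stronger inhibitor, a higher number a weaker inhibitor:

- compound 1 `CCn1c(NC(C)C)nc2c(C3CCNCC3)csc2c1=O`: 190 nM
- compound 2 `CCn1c(NC2CC2)nc2ccsc2c1=O`: 2600 nM

Within the data shown here, compound 2 gives the higher of the two numbers; the gap to compound 1 lies beyond the scatter, and compound 1 differs from compound 2 in more than one place, so the two values show only that compound 2 is the weaker inhibitor of the pair.

Compound 3 `CCn1c(NC(C)(C)C)nc2ccsc2c1=O` follows from compound 2 by one change: tert-butyl in place of cyclopropyl on a nitrogen on an aromatic ring. Among the measured compounds shown here, no pair of measured compounds shows this change on its own, so no measured step can anchor it. For compound 3 the expectation in this assay is a step from compound 2 of a 1.7-fold lower number from compound 2 to compound 3 (0.24 log units; within the scatter), that is a small shift toward a lower number, at the edge of the scatter. Compound 3 is therefore estimated at 1500 nM, with a range from 400 nM to 6000 nM.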

Compound 3, half-maximal inhibitory concentration: 1500 nM
For compound 3 middle estimate and measured number coincide at the digits printed; measured number inside the range.
By their numbers in this assay, from the lowest: compound 1; then compounds 3 and 2 (each within the scatter of the next).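

In this assay, tert-butyl in place of cyclopropyl on a nitrogen on an aromatic ring gives a 1.7-fold lower number from compound 2 to compound 3 (0.24 log units; within the scatter), so the two groups cannot be told apart here. At this position on the shared core, the three-membered ring of cyclopropyl is therefore not required for a reading of this size, and an open group with no ring serves equally. Nothing at hand accounts for this result.

On these data alone, whether a longer chain such as n-butyl, or a chain ending in an amine or a carboxylic acid, would read the same at this nitrogen remains open. Also open, as far as these compounds go, is how much of the lower number of compound 1 belongs to the extra group on its core, since compound 1 differs from compound 2 and compound 3 in more than one place.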